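Swapping Cyclohexyl for Methoxy: What Stability to Expect

A few compounds are considered here, and "the series" means these few. Any claim that something is new, unique, unknown or untested is made for them only; others in the source may bear on it.

Of the compounds shown here, three have been tested in an ADME assay on a cell-free system (plasma, Homo sapiens) for metabolic stability, read by LC-MS, with a stated time of 60 min, at 37 degrees C, tested at 50 uM; on this read-out lower numbers stand for a less stable compound and higher numbers for a more stable compound. Compound 1 `C[C@@H](O)[C@H]1C(=O)N2C(C(=O)OCc3oc(=O)oc3C(C)(C)C)=C(S[C@@H]3CN[C@H](C(=O)Nc4cccc(C(=O)OCc5oc(=O)oc5C(C)(C)C)c4)C3)[C@H](C)[C@H]12` gives 10%, compound 2 `C[C@@H](O)[C@H]1C(=O)N2C(C(=O)OCOC(=O)C3CCCCC3)=C(S[C@@H]3CN[C@H](C(=O)Nc4cccc(C(=O)O)c4)C3)[C@H](C)[C@H]12` gives 20%, and compound 3 `C[C@@H](O)[C@H]1C(=O)N2C(C(=O)OCOC(=O)C3CCCCC3)=C(S[C@@H]3CN[C@H](C(=O)Nc4cccc(C(=O)OCOC(=O)C5CCCCC5)c4)C3)[C@H](C)[C@H]12` gives 60%. Within the data shown here, compound 2 thus stands second highest of the three: its gap to compound 1 lies within the scatter, while compound 3 stands beyond it, the one measured step being a number 40 percentage points higher from compound 2 to compound 3 (beyond the scatter). Compound 4 `COC(=O)OCOC(=O)C1=C(S[C@@H]2CN[C@H](C(=O)Nc3cccc(C(=O)O)c3)C2)[C@H](C)[C@@H]2[C@@H]([C@@H](C)O)C(=O)N12` differs from compound 2 in one place: methoxy in place of cyclohexyl on a carbonyl carbon. Among the measured compounds shown here, no measured step touches this change; the step from compound 2 to compound 3 alters a different part of the molecule and gives no direct guide. A step no larger than the scatter is therefore expected, no change at the digits printed from compound 2 to compound 4 (within the scatter). Compound 4 is estimated at 20%, between 5% and 40%.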

Compound 4, percent of the compound remaining: 33%
The estimate for compound 4 lay 13 percentage points below the measured number; measured number inside the range.
By their numbers in this assay, from the lowest: compounds 1 and 2 (each within the scatter of the next); then compound 4; then compound 3.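

In this assay, the group on this carbonyl carbon turns out to matter: methoxy in place of cyclohexyl gives a number 13 percentage points higher from compound 2 to compound 4 (beyond the scatter). Among these compounds, the only earlier step changed a different part of the molecule, so this is the first reading at this position. Nothing available explains the rise. The swap removes a ring and brings in an oxygen at once, and the compounds shown cannot separate the two. A methyl on the same carbonyl carbon, which has neither ring nor oxygen, would help to tell them apart.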